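Dropping the Anilide Nitro Group from Compound 1

The source may hold more compounds than are shown below. What is called first, only, known or untested is meant among the compounds shown, and "the series" means these compounds.

Compound 1 `O=C(/C=C/C(=O)N1C/C(=C\c2ccc([N+](=O)[O-])cc2)C(=O)/C(=C/c2ccc([N+](=O)[O-])cc2)C1)Nc1ccc([N+](=O)[O-])cc1` is the more potent of the two measured compounds. In a functional assay on Molt4/C8 cells (Homo sapiens) for cytotoxicity (a lower number here means a stronger inhibitor, a higher number a weaker inhibitor), compound 1 gives 430 nM, the lowest of the two numbers recorded. For the measured compounds named here, the other measured compound, compound 2 `Cc1ccc(NC(=O)/C=C/C(=O)N2C/C(=C\c3ccccc3)C(=O)/C(=C/c3ccccc3)C2)cc1C`, gives 7900 nM in this assay; its number lies beyond the scatter away from that of compound 1, but the two structures differ in several places at once, so the two values show only that compound 1 is the stronger inhibitor of the pair.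

The unmeasured compound 3 `O=C(/C=C/C(=O)N1C/C(=C\c2ccc([N+](=O)[O-])cc2)C(=O)/C(=C/c2ccc([N+](=O)[O-])cc2)C1)Nc1ccccc1` changes compound 1 in a single place: hydrogen in place of nitro on an aromatic carbon. The other two nitro groups of compound 1 stay; only the anilino ring loses its nitro group. Going by the values given here, no pair of measured compounds differs in just this way, so the size of the step must be estimated. Since compound 2, which carries no nitro group at all, gives 7900 nM, some loss of potency is expected, though a modest one. The step is expected to be a 2.3-fold higher number from compound 1 to compound 3 (0.37 log units; beyond the scatter), toward a weaker compound. Compound 3 is expected to give about 1000 nM in this assay, within a range of 300 nM to 3500 nM.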

Compound 3, half-maximal inhibitory concentration: 360 nM
The estimate for compound 3 lay 2.8-fold (0.44 log units) above the measured number; the range from low to high includes it.
By their numbers in this assay, from the lowest: compounds 3 and 1 (each within the scatter of the next); then compound 2.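

In this assay, putting hydrogen in place of nitro on the anilino ring gives a 1.2-fold lower number from compound 1 to compound 3 (0.08 log units; within the scatter), so at this place, para to a large group, the nitro group can be removed without a change that stands out from the scatter. Compound 1 and compound 2 differ in several places at once, so that pair could say nothing about this one position, whereas compound 1 and compound 3 isolate it. The compounds shown offer no independent measurement that would explain this result.

The compounds shown leave open whether this position accepts other groups as readily, such as an amine, a carboxylic acid, a methoxy group or a chlorine atom. For the compounds shown here, they also leave open what the other two nitro groups, which compound 1 and compound 3 share, contribute, as no compound here differs from either of them at those places alone.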